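Adding fluoro to compound 3: notes toward compound 4

The compounds below may be only part of what the source reports. "The series", "measured", "known", "first", "only" and "open" are said of these compounds alone.

compound 1 `COc1ccc(-c2cncnc2-c2cc(OC)c(OC)c(OC)c2)cc1F`: 500 nM
compound 2 `CCSc1ccc(-c2cncnc2-c2cc(OC)c(OC)c(OC)c2)cc1`: 370 nM
compound 3 `CCOc1ccc(-c2cncnc2-c2cc(OC)c(OC)c(OC)c2)cc1`: 250 nM

All three values come from a functional assay on HeLa cells (Homo sapiens) for antiproliferative activity, read by CCK-8 assay, with a stated time of 72 h; a lower number here means a stronger inhibitor, a higher number a weaker inhibitor. There compound 3 gives 250 nM, and its steps to compound 1 and compound 2 both lie within the scatter, so the three compounds do not separate.

The next compound is compound 4 `CCOc1ccc(-c2cncnc2-c2cc(OC)c(OC)c(OC)c2)cc1F`. Its single structural difference is fluoro in place of hydrogen on an aromatic carbon. Going by the values given here, no measured step isolates this change. The closest evidence is a 2.0-fold lower number from compound 1 to compound 3 (0.30 log units; within the scatter), where 4-ethoxyphenyl replaces 3-fluoro-4-methoxyphenyl, so fluoro and the ether group change together. The other step involving that fluorinated ring, a 1.4-fold lower number from compound 1 to compound 2 (0.13 log units; within the scatter), likewise changes both at once. The step of a 1.5-fold lower number from compound 2 to compound 3 (0.17 log units; within the scatter) leaves fluoro out of the comparison altogether. All three steps are small, and none can assign a size to fluoro alone.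

Among the compounds with values here, the only fluorinated reference is compound 1 at 500 nM, which gives a weak hint toward a higher number. The expected change is a 1.2-fold higher number from compound 3 to compound 4 (0.08 log units; within the scatter), which is not expected to exceed the scatter. Compound 4 is estimated at 300 nM, with an expected range of 130 nM to 700 nM.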

Compound 4, half-maximal inhibitory concentration: 470 nM
Compound 4: middle estimate off by 1.6-fold (0.19 log units), on the low side; the measured number falls inside the stated range.
By their numbers in this assay, from the lowest: compounds 3, 2, 4 and 1 (each within the scatter of the next).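

In this assay, going by these compounds alone, the fluoro group, ortho to an ethoxy group, can now be read on its own: the step is a 1.9-fold higher number from compound 3 to compound 4 (0.27 log units; within the scatter) and stays within the scatter, so adding fluoro at this place does not separate the two compounds, a reading the earlier steps could not give since fluoro and the ether group always changed together. With fluoro held in place, the ether group can also be read alone: a 1.1-fold lower number from compound 1 to compound 4 (0.03 log units; within the scatter) is the smaller of the two new steps and likewise within the scatter, so on the fluorinated ring methoxy and ethoxy do not separate in this assay. No measurement shown gives a reason for the size of either step.

Still open, from the compounds shown here alone, is whether a chloro group, a hydroxy group or an amine at this same place, or a propoxy chain in place of ethoxy, would give a step beyond the scatter. Also open, going by these compounds, is whether fluoro on the ring of compound 2, with its ethylsulfanyl group, would behave as it does alongside ethoxy.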